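Methylamino for 2-oxo-1,3-oxazolidin-3-yl: compound 3

This account rests on a few compounds, and the source may have more. Where it says the series, first, only, none or still open, it means among the compounds named here.

In a functional assay on cells (Macrophage, Homo sapiens) for cytotoxicity (a lower number here means that less compound is tolerated, a higher number that more compound is tolerated), compound 1 `O=C(NN1CCOC1=O)c1[nH]c2ccc(Cl)cc2c1S(=O)(=O)c1ccccc1` gives > 100 uM, which is a limit and not a number. Compound 2 `Cc1cc(C)cc(S(=O)(=O)c2c(C(=O)NN3CCOC3=O)[nH]c3ccc(Cl)cc23)c1` gives > 100 uM, again only a limit. Together these form (the limit of > 100 uM in this assay, at which 2 of the 2 values shown sit). Compound 3 `CNNC(=O)c1[nH]c2ccc(Cl)cc2c1S(=O)(=O)c1cc(C)cc(C)c1` carries methylamino in place of 2-oxo-1,3-oxazolidin-3-yl on an amide-type nitrogen. Among the compounds with values here, the sole measured step, a step that the two limits leave unreadable from compound 1 to compound 2, is 3,5-dimethylphenyl in place of phenyl on a sulfonyl sulfur, so it offers no size to carry over. The expected at least 1.2-fold lower number from compound 2 to compound 3 (0.09 log units; that floor lies within the scatter) is modest and downward in this assay, though poorly defined. For compound 3 the estimate is 80 uM, with an expected range of 20 uM to 200 uM.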

Compound 3, half-maximal toxic concentration: > 100 uM
Compound 3: no number, only a limit; the forecaster's own chance of this, stated with the estimate: 55%; at least 1.2-fold (0.09 log units) between middle value and limit.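

In this assay compound 3 gives > 100 uM, a limit and not a number, so the step between compound 2 and compound 3 cannot be read: the limit of > 100 uM in this assay, at which 3 of the 3 values shown sit.

The compounds shown leave open whether either change alters tolerance at all.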